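Trimming one methoxy from the trimethoxy analogue

A few compounds are considered here, and "the series" means these few. Any claim that something is new, unique, unknown or untested is made for them only; others in the source may bear on it.

Among the measured compounds shown here, compound 2 `COc1cc(-c2cc(/C=C/C(=O)c3ccc(N)cc3)[nH]n2)cc(OC)c1OC` is the weaker-acting of the two measured members. In a functional assay on TK-10 cells (Homo sapiens) for cytotoxicity, read by sulforhodamine B assay, with a stated time of 48 h, tested at 1 uM (on this read-out lower numbers stand for a stronger effect and higher numbers for a weaker effect at the one concentration tested), compound 2 gives 102%, the highest number of the two and well beyond the scatter from its nearest neighbour. Compound 1 `COc1ccc(-c2cc(/C=C/C(=O)c3ccc(N)cc3)[nH]n2)cc1`, which carries a single methoxy group on the same aromatic ring, gives 81% in this assay. Compound 3 `COc1ccc(-c2cc(/C=C/C(=O)c3ccc(N)cc3)[nH]n2)cc1OC` has not yet been measured. The change from compound 2 to compound 3 is hydrogen in place of methoxy on an aromatic carbon, leaving two methoxy groups on that ring. For the measured compounds named here, no step between measured compounds is known, so the expectation rests on the two values shown. A move towards the number of compound 1 is expected, so a downward step of modest size, near the edge of the scatter, is estimated as a number 10 percentage points lower from compound 2 to compound 3 (within the scatter). Compound 3 is expected to give about 92% in this assay, within a range from 76% to 108%.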

Compound 3, a percentage reported as activity, at one concentration (the size of the read-out at that concentration, not a potency): 107%
The estimate for compound 3 lay 15 percentage points below the measured number; low and high end bracket the measured number.
By their numbers in this assay, from the lowest: compound 1; then compounds 2 and 3 (each within the scatter of the next).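

In this assay hydrogen in place of methoxy, on an aromatic carbon ortho to a methoxy group and meta to a large group, gives a number 5 percentage points higher from compound 2 to compound 3 (within the scatter) and so leaves no readable difference between these two groups at this position. Methoxy in place of hydrogen on an aromatic carbon gives a number 26 percentage points higher from compound 1 to compound 3 (beyond the scatter) as the one step beyond the scatter, so within this pair the added methoxy goes with a weaker effect at the one concentration tested. Nothing available here explains either step.

Open, as far as these compounds go, is whether a hydroxyl group or a fluorine atom in place of that added methoxy would stay near compound 1 or near compound 3. Also open, from the compounds shown here alone, is how the core of compound 1 behaves with no methoxy at all.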